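The source may report more compounds than this note shows. Statements on the series, on what has been measured and on what is new or still open speak of the compounds shown alone.

Measured compounds:
- compound 1, `COc1ccc(N2CCN(C(=S)SCc3ccc(C(=O)Nc4ccccc4N)cc3)CC2)cc1`: 39.4%
- compound 2, `CC1CCN(C(=S)SCc2ccc(C(=O)Nc3ccccc3N)cc2)CC1`: 46.8%

In a functional assay on HeLa cells (Homo sapiens) for antiproliferative activity, read by CCK-8 assay, with a stated time of 72 h, tested at 2 uM (a lower number here means a weaker effect, a higher number a stronger effect of the compound at the concentration tested), compound 1 gives 39.4% and compound 2 gives 46.8%. Compound 2 holds the higher of the two numbers, but compound 1 sits within the usual scatter of it, so the two values cannot be told apart with confidence, and neither compound can be called the more active one.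

Compound 3, `CN1CCN(C(=S)SCc2ccc(C(=O)Nc3ccccc3N)cc2)CC1`, is not yet measured. It is built from compound 2 by one change: 4-methylpiperazin-1-yl in place of 4-methylpiperidin-1-yl on a thiocarbonyl carbon. Among the compounds with values here, no pair of measured compounds that differ in only one place is available, so there is no measured step to lean on for this kind of change. Since compound 1 and compound 2 carry different rings at the same position yet give values within the scatter of each other, the expectation for this change in this assay is a step of no size beyond the scatter, in either direction.

Compound 3 is therefore expected to give about 42%, within a range from 25% to 60%, which means an expected step of a number 4.8 percentage points lower from compound 2 to compound 3 (within the scatter).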

Compound 3, a percentage reported as inhibition, at one concentration (the size of the read-out at that concentration, not a potency): 52.6%
The estimate for compound 3 lay 10.6 percentage points below the measured number, and the stated range covers the measured number.
By their numbers in this assay, from the lowest: compounds 1, 2 and 3 (each within the scatter of the next, the first and the last beyond it).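

In this assay the exchange of 4-methylpiperidin-1-yl for 4-methylpiperazin-1-yl on a thiocarbonyl carbon gives a number 5.8 percentage points higher from compound 2 to compound 3 (within the scatter) and so the second ring nitrogen, with its one hydrogen-bond acceptor, brings no readable difference in this read-out. The substituent on the amine nitrogen of the ring does give a first readable difference: methyl in place of 4-methoxyphenyl gives a number 13.2 percentage points higher from compound 1 to compound 3 (beyond the scatter) and this modest step is the only one here that clears the scatter. Nothing available explains either step.

The compounds shown leave open what other groups would do on that amine nitrogen in a ring, such as a longer chain like propyl, or a carboxylic acid carried on a short chain, and whether a morpholine ring on the thiocarbonyl carbon would fall with compound 2 and compound 3. On these data alone, each number also comes from a single concentration, so how these compounds compare in potency remains unknown.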